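The source may report more compounds than this note shows. Statements on the series, on what has been measured and on what is new or still open speak of the compounds shown alone.

In a functional assay on cells (Homo sapiens) for antiproliferative activity, read by MTT assay, with a stated time of 48 h (on this read-out lower numbers stand for stronger inhibition and higher numbers for weaker inhibition), compound 1, `Cn1c(N)c(-c2nc3ccccc3[nH]2)c2nc(C#N)c(C#N)nc21`, gives > 50000 nM, which is a limit of the assay and not a number. Compound 2, `CCn1c(N)c(-c2nc3ccccc3[nH]2)c2nc(C#N)c(C#N)nc21`, gives > 50000 nM, again only a limit. The two therefore stand at the limit of > 50000 nM in this assay, at which 2 of the 3 values shown sit, and a step that the two limits leave unreadable from compound 1 to compound 2 cannot be sized. For the measured compounds named here, compound 3, `CN(C)CCCn1c(N)c(-c2nc3ccccc3[nH]2)c2nc(C#N)c(C#N)nc21`, gives 1820 nM, the only true number. The data show an at least 27-fold lower number from compound 1 to compound 3 (1.43 log units; beyond the scatter) and an at least 27-fold lower number from compound 2 to compound 3 (1.43 log units; beyond the scatter).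

Compound 4, `CCCCn1c(N)c(-c2nc3ccccc3[nH]2)c2nc(C#N)c(C#N)nc21`, takes compound 3 one change further: methyl in place of dimethylamino on a saturated chain carbon, three bonds along the chain from an aromatic nitrogen. This is methyl in place of dimethylamino on a saturated chain carbon, three bonds along the chain from an aromatic nitrogen, so 3-(dimethylamino)propyl becomes butyl. The two large steps to compound 3 bear most directly on this change, since only compound 3 carries the dimethylamino group. Read in reverse, they point to a large move towards higher numbers in this assay, although the longer butyl chain has no measured precedent and could retain some activity. The expected change is a 16-fold higher number from compound 3 to compound 4 (1.22 log units; beyond the scatter), and the assay may well report only a limit. The estimate for compound 4 is 30000 nM, with an expected range of 6000 nM to 80000 nM.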

Compound 4, half-maximal inhibitory concentration: > 50000 nM
Compound 4: no number, only a limit (the forecaster's own chance of this, stated with the estimate: 50%); middle value at least 1.6-fold (0.22 log units) from the limit.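

In this assay the change from 3-(dimethylamino)propyl to butyl gives an at least 27-fold higher number from compound 3 to compound 4 (1.43 log units; beyond the scatter) and so leaves only a limit of the assay, not a number, for compound 4. The earlier steps shown here could not separate the dimethylamino group from the longer chain that carries it, whereas here the chain runs on to the same place and only the end group differs, so a longer alkyl chain alone does not bring back a number. Among the four compounds, only compound 3 gives a true number, and compound 4 joins compound 1 and compound 2 at one shared limit, so the steps among those three cannot be read: the limit of > 50000 nM in this assay, at which 3 of the 4 values shown sit.

On these data alone, it remains open whether a primary amine or a hydroxyl at the end of the same propyl chain would also give a number in this assay, and whether the dimethylamino group would do so on a shorter or a longer chain. How far compound 1, compound 2 and compound 4 lie past their shared limit, and whether they differ from one another, also stays unresolved.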